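Benzofuranyl aryl ketones: second methyl ether removed

A few compounds are considered here, and "the series" means these few. Any claim that something is new, unique, unknown or untested is made for them only; others in the source may bear on it.

Measured compounds:
compound 1 `CCc1oc2cc(OC)ccc2c1C(=O)c1ccc(OC)cc1` — "not determined" (no result reported)
compound 2 `CCc1oc2ccc(OC)cc2c1C(=O)c1ccc(O)cc1` — 2460 nM

Among the compounds with values here, only one number stands so far. In an assay for inhibition of solute carrier family 22 member 12 (Homo sapiens), read by scintillation counting, with a stated time of 60 min (on this read-out higher numbers stand for weaker inhibition and lower numbers for stronger inhibition), compound 2 gives 2460 nM. Within the data shown here, compound 1 carries a methoxy on each of the two aryl parts; for compound 1 the entry in this assay reads "not determined" (no result reported), so no step between measured compounds can be read and nothing is known yet about how the methyl ether on either ring matters here.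

Compound 3 `CCc1oc2ccc(O)cc2c1C(=O)c1ccc(O)cc1` is the next entry. It differs from compound 2 by hydrogen in place of methyl on an oxygen on an aromatic ring, the oxygen sitting on the shared core, so that compound 3 carries a hydroxy on both aryl parts.

Among the measured compounds shown here, with no step on record, the expectation leans only on the single value of compound 2 and the size of the change. A small shift in the direction of stronger inhibition is expected, and it may well stay within the usual scatter; the step from compound 2 to compound 3 is estimated at a 1.6-fold lower number from compound 2 to compound 3 (0.21 log units; within the scatter). For compound 3 the estimate in this assay is 1500 nM, with a range from 400 nM to 6000 nM.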

Compound 3, half-maximal inhibitory concentration: 2490 nM
Compound 3: middle estimate off by 1.7-fold (0.22 log units), on the low side, and the stated range covers the measured number.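

In this assay, within the data shown here, hydrogen in place of methyl on an oxygen on an aromatic ring of the shared core gives a 1.0-fold higher number from compound 2 to compound 3 (0.01 log units; within the scatter), the first step that can be read. At this place, methoxy and hydroxy are not told apart by the read-out: the methyl on that oxygen can go without a change beyond the scatter, at least with a hydroxy on the other aryl part, which is the only setting shown. No measurement at hand bears on why the two compounds stand level.

Steps involving compound 1 cannot be read, so the role of the oxygen substituent on the other aryl part remains open, as does the effect of a methoxy placed elsewhere on the shared core. Also open, going by these compounds, is whether a larger group on the core oxygen, such as an ethoxy or a longer chain, or an amine in place of that oxygen, would shift the number beyond the scatter.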